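Adding a Methyl Beside an Ether Oxygen: Expected Lipophilicity

The source may report more compounds than this note shows. Statements on the series, on what has been measured and on what is new or still open speak of the compounds shown alone.

Measured so far:
compound 1, `COC(=O)/C=C(C)/C=C/CC(C)CCCC(C)(C)OC`, 5
compound 2, `CCOC(=O)/C=C(C)/C=C/CC(C)CCCC(C)(C)OC`, 5.54
compound 3, `CCOC(C)(C)CCCC(C)C/C=C/C(C)=C/C(=O)OC(C)C`, 6.49

In a physicochemical assay for lipophilicity (a higher number here means a more lipophilic compound, a lower number a more polar compound), compound 1 gives 5 and compound 2 gives 5.54. The change between them, (methyl in place of hydrogen on a saturated chain carbon bound to an oxygen next to a carbonyl group), made a step of a number 0.54 log units higher from compound 1 to compound 2 (beyond the scatter). Compound 3, `CCOC(C)(C)CCCC(C)C/C=C/C(C)=C/C(=O)OC(C)C`, has the highest number of the three in this assay at 6.49; how its core differs from that of compound 1 is not broken down here.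

Compound 4, `CC(/C=C/CC(C)CCCC(C)(C)OC(C)C)=C\C(=O)OC(C)C`, is not yet measured. It differs from compound 3 by methyl in place of hydrogen on a saturated chain carbon bound to an oxygen on a saturated carbon and a saturated chain carbon. This is the same kind of change as the earlier one, yet the place is not the same: in compound 2 the methyl entered on a saturated chain carbon bound to an oxygen next to a carbonyl group, whereas here it enters on a saturated chain carbon bound to an oxygen on a saturated carbon and a saturated chain carbon.

Beside the earlier step of a number 0.54 log units higher from compound 1 to compound 2 (beyond the scatter), a step of a number 0.51 log units higher from compound 3 to compound 4 (beyond the scatter) in this assay is expected, because compound 2 rose against compound 1 by a number 0.54 log units higher from compound 1 to compound 2 (beyond the scatter) after the same kind of change. Compound 4 is therefore estimated at 7 in this assay, with a range from 6.6 to 7.4.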

Compound 4, partition coefficient: 6.9
For compound 4 the middle estimate is 0.10 log units above the measured one; the measured number falls inside the stated range.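

Methyl in place of hydrogen gave a step of a number 0.41 log units higher from compound 3 to compound 4 (beyond the scatter) in this assay and, in the other pair, a step of a number 0.54 log units higher from compound 1 to compound 2 (beyond the scatter) as well, so the number went up in both pairs and both steps are modest. This shows that the change gave a rise of modest size in two different settings, once on a saturated chain carbon bound to an oxygen next to a carbonyl group and once on a saturated chain carbon bound to an oxygen on a saturated carbon and a saturated chain carbon. It does not show that the step would carry to other cores or other places, since two pairs make only a small sample, and nothing measured here explains the size of either step.

The compounds shown leave open how the number would move if a longer chain, such as butyl, stood in place of the isopropyl of the isopropoxy group. They also leave open what the same methyl step would be on a core carrying an amine or a carboxylic acid.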